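A Branched Chain Tested Against an Unresponsive Series

The source may hold more compounds than are shown below. What is called first, only, known or untested is meant among the compounds shown, and "the series" means these compounds.

Compound 1, `CCCCCCOc1cccc(O)c1C(=O)/C=C/c1ccc(O)cc1`. In a functional assay on MDA-MB-231 cells (Homo sapiens) for antiproliferative activity, read by sulforhodamine B assay (on this read-out lower numbers stand for stronger inhibition of growth and higher numbers for weaker inhibition of growth), compound 1 gives > 30000 nM, which is a limit of the assay rather than a number.
Compound 2, `O=C(/C=C/c1ccc(O)cc1)c1c(O)cccc1OCC1CCCCC1`. In this assay compound 2 gives > 30000 nM, again a limit.
Compound 3, `O=C(/C=C/c1ccc(O)cc1)c1c(O)cccc1OCc1ccccc1`. In this assay compound 3 gives > 30000 nM, again a limit.

Compound 1 therefore stands nowhere definite on the numbers shown: only a limit is known for it, and the same holds for the two further values. The three compounds share one core and differ only in the group on a saturated chain carbon bound to an oxygen on an aromatic ring. The steps between them are a step that the two limits leave unreadable from compound 1 to compound 2, a step that the two limits leave unreadable from compound 1 to compound 3 and a step that the two limits leave unreadable from compound 2 to compound 3; none of them can be read, since every value involved sits at the limit of > 30000 nM in this assay, at which 3 of the 3 values shown sit.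

The unmeasured compound 4, `CC(C)CCCOc1cccc(O)c1C(=O)/C=C/c1ccc(O)cc1`, differs from compound 1 by isopropyl in place of propyl on a saturated chain carbon, three bonds along the chain from an oxygen on an aromatic ring. Going by the values given here, no measured step bears on this change with a readable size, so no direction or size can be drawn from them; the only guide is that all three measured values sit at the limit of > 30000 nM in this assay, at which 3 of the 3 values shown sit. Compound 4 is therefore expected to remain at that limit as well, with an estimated value of 40000 nM and a range from 15000 nM to 100000 nM. The step that the limit leaves unreadable from compound 1 to compound 4 in this assay is thus expected to show nothing beyond the scatter.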

Compound 4, concentration for 50% growth inhibition: 3480 nM
Beside the measured number, compound 4's estimate is 11-fold (1.06 log units) above it, outside the stated range (below it).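

Going by these compounds alone, compound 4 is the first compound here with a readable number in this assay, which shows that growth inhibition can respond to a change at this position: with the same atoms joined differently, the branched chain end gives an at least 8.6-fold lower number from compound 1 to compound 4 (0.93 log units; beyond the scatter). The isopentyl group of compound 4 also differs from the ring-bearing groups at the oxygen, with an at least 8.6-fold lower number from compound 3 to compound 4 (0.93 log units; beyond the scatter) and an at least 8.6-fold lower number from compound 2 to compound 4 (0.93 log units; beyond the scatter). These three steps give only a minimum size, and the steps among compound 1, compound 2 and compound 3 still cannot be read, because each of those three compounds stands at a limit of the assay rather than at a number: the limit of > 30000 nM in this assay, at which 3 of the 4 values shown sit.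

With only one branched chain shown, it remains open whether the lower number comes from branching in general or from this particular isopentyl group. Going by these compounds, a shorter branched chain such as isobutyl, or a chain ending in a tert-butyl group or an amine, would help to separate these possibilities, while the true size of the steps stays unknown.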